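Hydroxyphenyl isomers on a shared pyridine-free core: topoisomerase 1 inhibition

The source may hold more compounds than are shown below. What is called first, only, known or untested is meant among the compounds shown, and "the series" means these compounds.

Measured so far:
- compound 1 `Oc1ccc(-c2cc(-c3ccc(O)cc3)nc(-c3ccc(O)cc3)c2)cc1`: 3.8%
- compound 2 `Oc1ccc(-c2cc(-c3cccc(O)c3)cc(-c3ccc(O)cc3)n2)cc1`: 0%
- compound 3 `Oc1ccc(-c2cc(-c3ccccc3O)cc(-c3ccccc3O)n2)cc1`: 0.3%

All three were run in an assay on isolated protein for inhibition of DNA topoisomerase 1 (Homo sapiens), with a stated time of 30 min, tested at 100 uM (a higher number here means more inhibition at the concentration tested (going by the name of the read-out), a lower number less inhibition), and none gives more than a trace of inhibition. Compound 3 stands second highest of the three numbers; its nearest neighbour is compound 2, which sits a little lower, and the furthest is compound 1, which sits a little higher, both gaps within the scatter. Among the measured compounds shown here, the only single-point step in the set, a number 3.8 percentage points lower from compound 1 to compound 2 (within the scatter), is within the scatter as well.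

Compound 4 `Oc1ccc(-c2cc(-c3ccccc3O)cc(-c3ccc(O)cc3)n2)cc1` has not been measured. It differs from compound 3 by 4-hydroxyphenyl in place of 2-hydroxyphenyl on an aromatic carbon. The step from compound 1 to compound 2 also exchanges one hydroxyphenyl isomer for another on the shared core and produced no shift beyond the scatter; compound 2 and compound 3 differ in two places, so only their two values can be compared, and they lie close together. On this basis, no step beyond the scatter is expected, with a number 1.2 percentage points higher from compound 3 to compound 4 (within the scatter). Compound 4 is therefore estimated at 1.5%, with a range from 0% to 8%.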

Compound 4, a percentage reported as inhibition, at one concentration (the size of the read-out at that concentration, not a potency): 0.4%
Compound 4: middle estimate off by 1.1 percentage points, on the high side, and the stated range covers the measured number.
By their numbers in this assay, from the lowest: compounds 2, 3, 4 and 1 (each within the scatter of the next).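

In this assay, 4-hydroxyphenyl in place of 2-hydroxyphenyl on the aromatic carbon next to the ring nitrogen leaves the read-out within the scatter (a number 0.1 percentage points higher from compound 3 to compound 4 (within the scatter)), so this exchange of isomers at this position gives no readable change. The two other steps into compound 4 read the same way (a number 0.4 percentage points higher from compound 2 to compound 4 (within the scatter); a number 3.4 percentage points lower from compound 1 to compound 4 (within the scatter)), which extends the flat picture to exchanges involving 2-hydroxyphenyl, 3-hydroxyphenyl and 4-hydroxyphenyl on the shared core. No supporting data bear on why these isomers do not separate.

Still open, going by these compounds, is whether a group other than a hydroxyphenyl at this position, such as an aminophenyl or a carboxylic acid, would lift inhibition beyond a trace. With all four compounds read at a single concentration, any ranking among these isomers also remains unresolved.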